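A few compounds are considered here, and "the series" means these few. Any claim that something is new, unique, unknown or untested is made for them only; others in the source may bear on it.

Of the compounds shown here, three that share one core have been tested in an ADME assay on GES1 cells (Homo sapiens) for inhibition, read by MTT assay, with a stated time of 72 h; a higher number here means a weaker inhibitor, a lower number a stronger inhibitor. Compound 1 `Cc1cc(Nc2ccn(Cc3ccccc3)n2)n2nc(SCc3ccc(Br)cc3)nc2n1` gives 44400 nM in this assay. Compound 2 `Cc1cc(Nc2cc(-c3ccccc3)[nH]n2)n2nc(SCc3ccccc3Br)nc2n1` gives 41100 nM, and compound 3 `Cc1cc(Nc2cc(-c3ccc(Cl)cc3)[nH]n2)n2nc(SCc3ccc(Br)cc3)nc2n1` gives 28200 nM. Among these three numbers compound 2 stands second highest, yet its gap to compound 1 and its gap to compound 3 both lie within the scatter of repeated measurements, so the three compounds cannot be told apart on this assay and none of them can be called the strongest or the weakest.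

Compound 4 `Cc1cc(Nc2cc(-c3ccccc3)[nH]n2)n2nc(SCC3CC3)nc2n1` has not yet been measured. It differs from compound 2 in one place: cyclopropyl in place of 2-bromophenyl on a saturated chain carbon bound to a sulfur. Among the compounds with values here, no pair of measured compounds that differ in a single place is available, so the effect of a change of this kind is not known from these data. What the three measured compounds do show is that they sit close together, and nothing in their numbers points to a large move in either direction.

The step from compound 2 to compound 4 in this assay is expected to be a 1.0-fold lower number from compound 2 to compound 4 (0.01 log units; within the scatter), a step no larger than the scatter. Compound 4 is estimated to give 40000 nM in this assay, with a likely range from 15000 nM to 100000 nM.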

Compound 4, half-maximal inhibitory concentration: > 50000 nM
Compound 4 gave a limit, no number; the forecaster's own chance of this, stated with the estimate: 20%; at least 1.2-fold (0.09 log units) between middle value and limit.
By their numbers in this assay, from the lowest: compounds 3, 2 and 1 (each within the scatter of the next). At a limit, above all of these: compound 4.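

Within the data shown here, this is the first change at a single place that can be read, and it concerns the group on a saturated chain carbon bound to a sulfur. Going by these compounds, putting cyclopropyl in place of 2-bromophenyl in this assay gives an at least 1.2-fold higher number from compound 2 to compound 4 (0.08 log units; that floor lies within the scatter), so the change shows no sign of a stronger inhibitor, but its true size remains unknown and only this floor can be stated. Compound 4 stands at a limit and not at a number, which is why the step has no upper end: the limit of > 50000 nM in this assay, at which 1 of the 4 values shown sits.

The change replaces the aromatic ring and removes the bromine in one move, so the compounds shown cannot separate what each of these contributes, and a single step says little about this place in general. Also open, on these data alone, is how this place would respond to other groups, such as a longer chain like butyl, a chain ending in an amine or one ending in a carboxylic acid, and whether any of them would give a number clearly apart from compound 2.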